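The source may hold more compounds than are shown below. What is called first, only, known or untested is meant among the compounds shown, and "the series" means these compounds.

Among the compounds with values here, compound 3 `O=C(O)Cc1sc(C(c2ccc(F)cc2)c2ccc(F)cc2)nc1-c1ccc(Cl)cc1` gives 9.7 nM in an in vitro assay on HEK385-7 cells for displacement of a labelled ligand from prostaglandin D2 receptor 2 (Homo sapiens) (a lower number here means a stronger inhibitor, a higher number a weaker inhibitor), the lowest of the three numbers measured so far; compound 1 `O=C(O)Cc1sc(C(c2ccc(F)cc2)c2ccc(F)cc2)nc1-c1ccnc(N2CCCC2)c1` gives 230 nM and compound 2 `NS(=O)(=O)c1ccc(-c2nc(C(c3ccc(F)cc3)c3ccc(F)cc3)sc2CC(=O)O)cc1` gives 1500 nM. The steps to it are a 24-fold lower number from compound 1 to compound 3 (1.37 log units; beyond the scatter) and a 150-fold lower number from compound 2 to compound 3 (2.19 log units; beyond the scatter), while between the two weaker compounds there is a 6.5-fold higher number from compound 1 to compound 2 (0.81 log units; beyond the scatter). Compound 4 `Cc1cc(-c2nc(C(c3ccc(F)cc3)c3ccc(F)cc3)sc2CC(=O)O)ccn1` has not yet been measured and differs from compound 3 in one place: 2-methylpyridin-4-yl in place of 4-chlorophenyl on an aromatic carbon. Within the data shown here, two measured steps bear on this change, a 24-fold lower number from compound 1 to compound 3 (1.37 log units; beyond the scatter) and a 150-fold lower number from compound 2 to compound 3 (2.19 log units; beyond the scatter); in both, 4-chlorophenyl gave a lower number than a group carrying a hetero atom. The entering 2-methylpyridin-4-yl and the 2-(pyrrolidin-1-yl)pyridin-4-yl of compound 1 are both pyridin-4-yl groups, though the group on each ring differs, so that step is only a partial guide. The chemist therefore expects a higher number, beyond the scatter, a 12-fold higher number from compound 3 to compound 4 (1.09 log units; beyond the scatter). For compound 4 the estimate in this assay is 120 nM, with a range from 30 nM to 500 nM.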

Compound 4, half-maximal inhibitory concentration: 3.1 nM
Beside the measured number, compound 4's estimate is 39-fold (1.59 log units) above it, outside the stated range (below it).
By their numbers in this assay, from the lowest: compound 4; then compound 3; then compound 1; then compound 2.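

In this assay, the aromatic carbon next to the ring nitrogen accepts a six-membered aromatic ring with a hetero atom: a 3.1-fold lower number from compound 3 to compound 4 (0.50 log units; beyond the scatter), so a ring nitrogen in this group does not by itself raise the number, as the comparisons with compound 1 and compound 2 had left possible. Among the pyridin-4-yl groups, the substituent on the ring matters greatly, with methyl in place of pyrrolidin-1-yl giving a 74-fold lower number from compound 1 to compound 4 (1.87 log units; beyond the scatter). The widest step among these compounds comes with 2-methylpyridin-4-yl in place of 4-sulfamoylphenyl, a 480-fold lower number from compound 2 to compound 4 (2.68 log units; beyond the scatter).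

No measured evidence accounts for any of these steps. Going by these compounds, it remains open how the step from 4-chlorophenyl divides between the ring nitrogen and the methyl, which a plain pyridin-4-yl or a 4-methylphenyl group would help to separate.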